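This account rests on a few compounds, and the source may have more. Where it says the series, first, only, none or still open, it means among the compounds named here.

Working notes, series of biphenyl acids measured in an in vitro functional assay on cells for agonist activity at Bombesin receptor subtype-3 (Homo sapiens), read by luminescence and calcium flux; on this read-out higher numbers stand for an effect only at larger amounts of compound and lower numbers for an effect already at smaller amounts. Compound 1 `CCCCc1cnc(C(CCCC)Cc2ccc(-c3ccccc3C(=O)O)cc2)[nH]1` gives 2660 nM and compound 2 `CCCCc1cnc(C(CC)Cc2ccc(-c3ccccc3C(=O)O)cc2)[nH]1` gives 2720 nM; the step of a 1.0-fold higher number from compound 1 to compound 2 (0.01 log units; within the scatter). Compound 3 `O=C(O)c1ccccc1-c1ccc(CCc2ncc(CC3CCCCCC3)[nH]2)cc1` gives 88 nM, the lowest of the three numbers and beyond the scatter from both others. Compound 4 `CC(C)(C)CCc1cnc(CCc2ccc(-c3ccccc3C(=O)O)cc2)[nH]1` is unmeasured; it differs from compound 3 by neopentyl in place of cycloheptyl on a saturated chain carbon bound to an aromatic carbon. For the measured compounds named here, no measured step touches this change: the single step, from compound 1 to compound 2, concerns another part of the shared core and stayed within the scatter. Compounds 1 and 2 differ from compound 3 in more than one place, so their gap to it is only a hint. For compound 4 a moderate rise is expected, a 4.0-fold higher number from compound 3 to compound 4 (0.60 log units; beyond the scatter). Compound 4 is estimated at 350 nM, range 110 nM to 1200 nM.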

Compound 4, half-maximal effective concentration: 39 nM
Compound 4: middle estimate off by 9.0-fold (0.95 log units), on the high side, and the stated range ends above it.
By their numbers in this assay, from the lowest: compound 4; then compound 3; then compounds 1 and 2 (each within the scatter of the next).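

Neopentyl in place of cycloheptyl on a saturated chain carbon bound to an aromatic carbon gives a 2.3-fold lower number from compound 3 to compound 4 (0.35 log units; beyond the scatter) in this assay and so shows that the seven-membered ring is not required at this place for a low number. For the compounds shown here, this is the first measured step at this position, and an open, branched group serves here at least as well as the ring. Nothing measured bears on the reason for this step.

Only these two groups are compared at this position, so ring loss and the change in heavy atoms remain unseparated. A cyclohexyl group or a chain carrying an amine would test how far this position tolerates change.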